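The source may report more compounds than this note shows. Statements on the series, on what has been measured and on what is new or still open speak of the compounds shown alone.

Measured compounds in a functional assay on HCT-116 cells (Homo sapiens) for cytotoxicity; on this read-out higher numbers stand for weaker inhibition and lower numbers for stronger inhibition:
- compound 1 `CSc1ccc(C2=C(c3cccs3)C(=O)N3CCCC3C2)cc1`: 270 nM
- compound 2 `CSc1ccc(C2=C(c3ccco3)C(=O)N3CCCC3C2)cc1`: 3000 nM

Compound 2 stands at the higher of the two numbers; the step of an 11-fold higher number from compound 1 to compound 2 (1.05 log units; beyond the scatter) separates it from compound 1. Compound 3 `CSc1ccc(C2=C(c3ccoc3)C(=O)N3CCCC3C2)cc1` follows from compound 2 by furan-3-yl in place of furan-2-yl on a double-bonded ring carbon. Among the measured compounds shown here, no measured step touches this kind of change: the only step on record, from compound 1 to compound 2, swaps one five-membered aromatic ring for another of different hetero atom, whereas here the same ring is kept and only the point of attachment moves. That single step therefore offers no direct guide to direction or size. On this basis compound 3 is expected to land near compound 2 in this assay, with a step of a 1.5-fold lower number from compound 2 to compound 3 (0.18 log units; within the scatter) that may well stay within the scatter, and the estimate for compound 3 is 2000 nM, ranging from 600 nM to 7000 nM.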

Compound 3, half-maximal inhibitory concentration: 1100 nM
Compound 3: the middle estimate sits 1.8-fold (0.26 log units) above what was measured; the measured number falls inside the stated range.
By their numbers in this assay, from the lowest: compound 1; then compound 3; then compound 2.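

In this assay the point of attachment matters on its own: with the atoms unchanged, furan-3-yl in place of furan-2-yl gives a 2.7-fold lower number from compound 2 to compound 3 (0.44 log units; beyond the scatter) on the double-bonded ring carbon, so this position responds to how the ring is joined and not only to which hetero atom it carries. The gain is partial: furan-3-yl in place of thiophen-2-yl still gives a 4.1-fold higher number from compound 1 to compound 3 (0.61 log units; beyond the scatter) and compound 1 keeps the lowest number of the three. Nothing on hand accounts for either step.

Open, from the compounds shown here alone, is whether thiophen-3-yl on this carbon would move away from thiophen-2-yl in the same direction as the furans move from each other. Also open, going by these compounds, is how a six-membered aromatic ring, such as phenyl or pyridin-3-yl, would read at this position.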